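Replacing Cyclopentylsulfanyl with a Directly Attached Cyclohexyl

The source may report more compounds than this note shows. Statements on the series, on what has been measured and on what is new or still open speak of the compounds shown alone.

Three compounds share one core and differ only in the group on a single aromatic carbon. Compound 3 `CC(C(=O)NCc1ccc(C(F)(F)F)cc1SC1CCCC1)c1ccc(NS(C)(=O)=O)c(F)c1` carries a cyclopentylsulfanyl group there; in an assay on CHO cells for antagonist activity at transient receptor potential cation channel subfamily V member 1 (Homo sapiens), read by FLIPR (on this read-out lower numbers stand for stronger inhibition and higher numbers for weaker inhibition), compound 3 gives 0.3 nM. Compound 1 `CC(C(=O)NCc1ccc(C(F)(F)F)cc1OC1CCCC1)c1ccc(NS(C)(=O)=O)c(F)c1`, with cyclopentyloxy in that place, gives 0.6 nM in this assay, and compound 2 `CC(C(=O)NCc1ccc(C(F)(F)F)cc1OCc1ccc(F)cc1)c1ccc(NS(C)(=O)=O)c(F)c1`, with (4-fluorobenzyl)oxy, gives 0.5 nM. On the numbers shown compound 3 sits at the low end, but the step of a 2.0-fold lower number from compound 1 to compound 3 (0.30 log units; within the scatter) and the step of a 1.7-fold lower number from compound 2 to compound 3 (0.22 log units; within the scatter) both lie within the scatter, so the three compounds stand level.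

Compound 4 `CC(C(=O)NCc1ccc(C(F)(F)F)cc1C1CCCCC1)c1ccc(NS(C)(=O)=O)c(F)c1` alters compound 3 by cyclohexyl in place of cyclopentylsulfanyl on an aromatic carbon. For the measured compounds named here, two measured steps bear on this indirectly: a 2.0-fold lower number from compound 1 to compound 3 (0.30 log units; within the scatter) shows that exchanging the oxygen of the linker for sulfur changed little, and a 1.2-fold lower number from compound 1 to compound 2 (0.08 log units; within the scatter) shows that exchanging the ring carried on that oxygen changed little either. Going by the values given here, no measured step removes the linking atom and attaches the ring directly to the aromatic carbon, so that part of the change is untested. The author therefore expects compound 4 to stay in the same low range, with a modest move toward a higher number possible, estimated as a 3.3-fold higher number from compound 3 to compound 4 (0.52 log units; beyond the scatter) in this assay. The estimate for compound 4 is 1 nM, with a range from 0.3 nM to 4 nM.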

Compound 4, inhibition constant: 0.6 nM
The estimate for compound 4 lay 1.7-fold (0.22 log units) above the measured number; the range from low to high includes it.
By their numbers in this assay, from the lowest: compounds 3, 2, 1 and 4 (each within the scatter of the next).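

In this assay, the directly attached cyclohexyl stands level with all three linked groups: the record shows a 2.0-fold higher number from compound 3 to compound 4 (0.30 log units; within the scatter), a 1.2-fold higher number from compound 2 to compound 4 (0.08 log units; within the scatter) and no change at the digits printed from compound 1 to compound 4 (within the scatter). The earlier compounds shown here all joined their group to this aromatic carbon through an oxygen or a sulfur, so they could show only that exchanging the linking atom or the group it carries left the number within the scatter; compound 4 adds that a cyclohexyl ring with no linking atom, and with no hydrogen-bond acceptor where cyclopentylsulfanyl has one, also stands level with them at this place. No measurement is available that explains why these four groups behave alike here.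

The compounds shown leave open how far this level behaviour extends, since every group here has six or more heavy atoms and contains a non-aromatic or aromatic ring. Whether an amine, a carboxylic acid, a longer open alkyl chain or plain hydrogen on this aromatic carbon would stay level with these four compounds in this assay is not answered by them.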